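Fluoro to trifluoromethoxy in a series without measurable potency

This account rests on a few compounds, and the source may have more. Where it says the series, first, only, none or still open, it means among the compounds named here.

Compound 1 `Cc1ccc2nc(-c3ccccc3F)[nH]c(=O)c2c1`, compound 2 `Cc1ccc2nc(-c3cccc(F)c3)[nH]c(=O)c2c1` and compound 3 `Cc1ccc2nc(-c3cccc(OC(F)(F)F)c3)[nH]c(=O)c2c1` share one core and differ only in the group on the pendant aryl ring. In a functional assay on HeLa cells (Homo sapiens) for cytotoxicity, read by MTT assay, with a stated time of 2 days (a higher number here means a weaker inhibitor, a lower number a stronger inhibitor), compound 1 gives > 50000 nM, which is a limit of the assay and not a number. Compound 2 likewise gives only a limit, > 50000 nM. Compound 3 also stays at a limit, > 50000 nM. The change from compound 2 to compound 3 is trifluoromethoxy in place of fluoro on an aromatic carbon; the step it made, a step that the two limits leave unreadable from compound 2 to compound 3, cannot be read because both values sit at the limit (the limit of > 50000 nM in this assay, at which 3 of the 3 values shown sit). How compound 1 differs from compound 2 is not broken down here.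

Compound 4 `Cc1ccc2nc(-c3ccccc3OC(F)(F)F)[nH]c(=O)c2c1` has not yet been measured in this assay. It differs from compound 1 by trifluoromethoxy in place of fluoro on an aromatic carbon. This is the same kind of change as that from compound 2 to compound 3, but not the same change: in compound 4 the trifluoromethoxy sits ortho to a large group, whereas in compound 3 it sits meta to a large group. The step from compound 1 to compound 4 is expected to be a step that the limit leaves unreadable from compound 1 to compound 4, an expectation resting on the fact that all three measured compounds sit at the limit (the limit of > 50000 nM in this assay, at which 3 of the 3 values shown sit), so that no step in either direction has yet been resolved. Compound 4 is accordingly expected to give about 60000 nM in this assay, within a range from 20000 nM to 200000 nM, and most probably to be reported again only as a limit.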

Compound 4, half-maximal inhibitory concentration: 850 nM
For compound 4 the middle estimate is 71-fold (1.85 log units) above the measured one, and the stated range ends above it.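

In this assay, trifluoromethoxy in place of fluoro, ortho to a large group, gives an at least 58-fold lower number from compound 1 to compound 4 (1.76 log units; beyond the scatter), so this single exchange can carry a large step in this series. The same exchange at the other placement on the aryl ring, from compound 2 to compound 3, cannot be read, because both compounds sit at a limit: the limit of > 50000 nM in this assay, at which 3 of the 4 values shown sit.

Compound 3 gives > 50000 nM, a limit of the assay and not a number, so the exchange reaches a readable value on one parent only, and one pair does not show that it carries over in general or why the outcome differs between the two placements.

Still open, on these data alone, is whether the readable value belongs to trifluoromethoxy itself or would also follow from another group at that same place, such as methoxy, trifluoromethyl, an amine or a carboxylic acid. Also open, as far as these compounds go, is whether a longer chain there would hold the step, and whether the result in this one cell assay would extend to any other cell line.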